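The source may hold more compounds than are shown below. What is called first, only, known or untested is meant among the compounds shown, and "the series" means these compounds.

Measured compounds:
- compound 1 `CCNC(=O)c1noc(-c2cc(C(C)C)c(O)cc2O)c1-c1cc(CNC(C)=O)no1` gives 167 nM in a functional assay on HCT-116 cells (Homo sapiens) for inhibition; a lower number here means a stronger inhibitor, a higher number a weaker inhibitor
- compound 2 `CCNC(=O)c1noc(-c2cc(C(C)C)c(O)cc2O)c1-c1cc(CN(CC)CC)no1` gives 38 nM in this assay
- compound 3 `CCNC(=O)c1noc(-c2cc(C(C)C)c(O)cc2O)c1-c1cc(CN2CCCC2)no1` gives 51 nM in this assay

Compound 1 stands with the highest number of the three; compound 3 is nearest with a 3.3-fold lower number from compound 1 to compound 3 (0.52 log units; beyond the scatter), and compound 2 furthest with a 4.4-fold lower number from compound 1 to compound 2 (0.64 log units; beyond the scatter). Between compound 2 and compound 3 the step is a 1.3-fold higher number from compound 2 to compound 3 (0.13 log units; within the scatter).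

Compound 4 `CCNC(=O)c1noc(-c2cc(C(C)C)c(O)cc2O)c1-c1ccn(C)n1` is not yet measured in this assay. It differs from compound 1 by 1-methyl-1H-pyrazol-3-yl in place of 3-(acetamidomethyl)-1,2-oxazol-5-yl on an aromatic carbon. Among the compounds with values here, no measured step covers this exchange. The two measured steps from compound 1 touch the same acetamidomethyl group that leaves here, and both gave lower numbers once the acetamido was replaced, which shows that the acetamido in compound 1 is not needed for the measured potency. What the change of ring and the loss of the whole side chain do is not covered. The step expected in this assay is therefore small and uncertain, leaning towards a somewhat lower number.

Compound 4 is estimated at 110 nM in this assay, within 35 nM to 350 nM, an expected step of a 1.5-fold lower number from compound 1 to compound 4 (0.18 log units; within the scatter).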

Compound 4, half-maximal inhibitory concentration: 16 nM
For compound 4 the middle estimate is 6.9-fold (0.84 log units) above the measured one; the measured number lies below the stated range.
By their numbers in this assay, from the lowest: compound 4; then compounds 2 and 3 (each within the scatter of the next); then compound 1.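

In this assay, the position on the five-membered aromatic ring with 1 nitrogen and 1 oxygen does not depend on the 3-(acetamidomethyl)-1,2-oxazol-5-yl group: placing 1-methyl-1H-pyrazol-3-yl there gives a 10-fold lower number from compound 1 to compound 4 (1.02 log units; beyond the scatter). The earlier compounds shown here varied only the end of the side chain, whereas this exchange removes both the chain and the ring that carries it, and the entering group has fewer heavy atoms and no hydrogen-bond donor. No measurement at hand accounts for the size of this step.

The compounds shown do not separate the effect of the ring exchange from that of losing the side chain; an unsubstituted 1,2-oxazol-5-yl group would address this. Also open, going by these compounds, is how an ethyl or cyclopropyl group in place of the methyl on the pyrazole would read out.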